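This account rests on a few compounds, and the source may have more. Where it says the series, first, only, none or still open, it means among the compounds named here.

Measured so far:
- compound 1, `CC(C)(c1cc([C@]23CCOC[C@H]2C3)nc(-c2ccc(NC(=S)NCCO)cc2)n1)S(C)(=O)=O`, in an ADME assay on microsomes (Homo sapiens) for metabolic stability (a lower number here means slower removal, a higher number faster removal of the compound), gives 3.1 mL.min-1.g-1
- compound 2, `CCNC(=O)Nc1ccc(-c2nccc([C@@]34CCOC[C@@H]3C4)n2)cc1`, in this assay gives 1.4 mL.min-1.g-1

Of these two, compound 2 stands lowest, so it is removed more slowly. The nearest number is that of compound 1, which is higher by a step beyond the usual scatter, so the two compounds are genuinely different in this assay.

The next compound is compound 3, `CCNC(=O)Nc1ccc(-c2nccc([C@]34CCOC[C@H]3C4)n2)cc1`, which is built from compound 2 by this change: the two compounds have the same atoms and bonds and differ only in configuration as drawn: 2 of 2 stereo elements differ (all stereocentres are inverted: mirror images); a stereocentre at a saturated ring carbon is drawn S in compound 2 and R in compound 3; a stereocentre at a saturated ring carbon is drawn R in compound 2 and S in compound 3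

For the measured compounds named here, no step between two measured compounds of this kind has been seen here, so there is no example to lean on. Since both compounds carry the same atoms and bonds, the expected step from compound 2 to compound 3 is no change at the digits printed from compound 2 to compound 3 (within the scatter), that is, none beyond the scatter. The estimate for compound 3 is therefore 1.4 mL.min-1.g-1, with a range from 0.7 mL.min-1.g-1 to 2.8 mL.min-1.g-1.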

Compound 3, intrinsic clearance in microsomes: 1.5 mL.min-1.g-1
Compound 3: middle estimate off by 1.1-fold (0.03 log units), on the low side; measured number inside the range.
By their numbers in this assay, from the lowest: compounds 2 and 3 (each within the scatter of the next); then compound 1.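

In this assay, the step is a 1.1-fold higher number from compound 2 to compound 3 (0.03 log units; within the scatter). For the compounds shown here, this is the first comparison here that tests configuration alone, and it can be read cleanly for one reason: the fact that compounds 2 and 3 differ only in the configuration as drawn. For this pair of mirror images, inverting both stereocentres gives no difference that can be told apart from the normal spread of repeated measurements, so the drawn configuration does not separate them in this assay.

Going by these compounds alone, the finding covers only this one pair, so it remains open whether mirror images would stay this close if another group, such as a primary amine or a carboxylic acid, were attached to the shared core. On these data alone, it also remains open whether inverting just one of the two stereocentres, giving a compound that is not a mirror image, would behave the same way.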